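The compounds below may be only part of what the source reports. "The series", "measured", "known", "first", "only" and "open" are said of these compounds alone.

Measured so far in a functional assay on the whole organism (strain Kunming) with Mus musculus as the target, with a stated time of 0.5 h; a lower number here means that less compound is needed, a higher number that more compound is needed for the effect:
- Compound 1 `COc1cc(OC)c(OC)cc1/C=C/COC(=O)/C=C/c1ccccc1C(F)(F)F`: > 710 umol/kg
- Compound 2 `COc1cc(OC)c(OC)cc1/C=C/COC(=O)/C=C/c1ccc(OC)c(OC)c1OC`: > 674 umol/kg

Compound 1 gives > 710 umol/kg, which is a limit and not a number. Compound 2 gives > 674 umol/kg, which is also a limit. Compound 1 therefore has no measured dose and cannot be ranked against compound 2.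

Compound 3 `COc1cc(OC)c(OC)cc1/C=C/COC(=O)/C=C/c1ccc(F)cc1` carries 4-fluorophenyl in place of 2-(trifluoromethyl)phenyl on a double-bonded chain carbon bound to a double-bonded chain carbon. Among the compounds with values here, no measured step is available as a guide, so only a modest move towards a lower dose is expected in this assay, and another limit remains quite possible. The expected step is an at least 1.5-fold lower number from compound 1 to compound 3 (0.19 log units; that floor lies within the scatter). For compound 3 the estimate is 450 umol/kg. The estimated range for compound 3 runs from 180 umol/kg to 810 umol/kg.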

Compound 3, dose for half-maximal effect: > 805 umol/kg
Compound 3 was reported as a limit; the forecaster's own chance of this, stated with the estimate: 50%; middle value at least 1.7-fold (0.25 log units) away from the limit.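

Within the data shown here, compound 1 and compound 3 are both reported only as limits, so no step between them can be read. Still open is whether 4-fluorophenyl or 2-(trifluoromethyl)phenyl gives the lower dose, and what actual dose any compound shown requires.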